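From allyl to cyclopropyl on the amide nitrogen

A few compounds are considered here, and "the series" means these few. Any claim that something is new, unique, unknown or untested is made for them only; others in the source may bear on it.

In a functional assay on the whole organism with Canis familiaris (Canis lupus familiaris) as the target (on this read-out lower numbers stand for an effect already at smaller amounts and higher numbers for an effect only at larger amounts of compound), compound 1 `CCC(CC)Nc1ncnc2c1ncn2C1O[C@H](C(=O)NC(C)C)[C@@H](O)[C@H]1O` gives 0.23 nM, while compound 2 `C=CCNC(=O)[C@H]1OC(n2cnc3c(NC(CC)CC)ncnc32)[C@H](O)[C@@H]1O` gives 0.078 nM, the lower of the two numbers. Within the data shown here, the only measured step is a 2.9-fold lower number from compound 1 to compound 2 (0.47 log units; beyond the scatter), with allyl in place of isopropyl on an amide-type nitrogen. Compound 3 `CCC(CC)Nc1ncnc2c1ncn2C1O[C@H](C(=O)NC2CC2)[C@@H](O)[C@H]1O` has not yet been measured. It differs from compound 2 at that same nitrogen, carrying cyclopropyl in place of allyl on an amide-type nitrogen. Among the measured compounds shown here, no measured compound carries cyclopropyl, so the single step from compound 1 is the only guide, and it shows only that a change at this nitrogen can move the number modestly. Compound 3 gives up the double bond of the allyl group, which compound 1 also lacks, so it may drift toward the higher number of compound 1. Only a small step is therefore expected, estimated as a 1.8-fold higher number from compound 2 to compound 3 (0.25 log units; within the scatter). In this assay compound 3 is expected to give about 0.14 nM, within an estimated range of 0.045 nM to 0.43 nM.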

Compound 3, half-maximal effective concentration: 1.9 nM
Compound 3: the middle estimate sits 14-fold (1.13 log units) below what was measured; measured number above the stated range.
By their numbers in this assay, from the lowest: compound 2; then compound 1; then compound 3.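

In this assay, the amide nitrogen proves far more sensitive than the earlier step suggested. The step of a 2.9-fold lower number from compound 1 to compound 2 (0.47 log units; beyond the scatter) had shown only a modest shift, whereas exchanging allyl for cyclopropyl, two groups made of the same atoms joined differently, gives a 24-fold higher number from compound 2 to compound 3 (1.39 log units; beyond the scatter). Cyclopropyl also compares poorly with isopropyl, with an 8.3-fold higher number from compound 1 to compound 3 (0.92 log units; beyond the scatter), so compound 3 has the highest number of the series, and the absence of the double bond does not alone set the value, since compound 1 and compound 3 both lack it yet differ beyond the scatter. No measurement available here explains why closing the three-membered ring carries such a cost.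

Going by these compounds, it remains open whether a straight propyl or a cyclobutyl on the same nitrogen would fall near compound 2 or near compound 3, and so whether the high number belongs to cyclopropyl alone or to ring groups at this position more generally. All three compounds share the same core and the same read-out, so it is also unknown whether this order would hold on another core or in any other kind of test.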